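This account rests on a few compounds, and the source may have more. Where it says the series, first, only, none or still open, it means among the compounds named here.

Working notes on the series. Compound 1 `COc1ccc(S(=O)(=O)/C=C/c2ccccn2)cc1`, compound 2 `COc1ccc(S(=O)(=O)/C=C/c2ncccc2F)cc1` and compound 3 `COc1ccc(S(=O)(=O)/C=C/c2cccnc2)cc1` have been run in an ADME assay on BV-2 cells (Mus musculus) for cytotoxicity, with a stated time of 24 h, tested at 50 uM; a higher number here means a weaker effect of the compound at the concentration tested, a lower number a stronger effect. In this assay compound 1 gives 100%, compound 2 gives 86.6% and compound 3 gives 85.8%. Compound 1 to compound 2 is fluoro in place of hydrogen on an aromatic carbon, and it gave a number 13.4 percentage points lower from compound 1 to compound 2 (beyond the scatter). The two cores differ as pyridin-3-yl in place of pyridin-2-yl on a double-bonded chain carbon bound to a double-bonded chain carbon, with a number 14.2 percentage points lower from compound 1 to compound 3 (beyond the scatter). The values of compound 2 and compound 3 lie within the scatter of each other.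

Compound 4 `COc1ccc(S(=O)(=O)/C=C/c2ccc(F)nc2)cc1` is not yet measured. Compound 3 to compound 4 is fluoro in place of hydrogen on an aromatic carbon. This is the same kind of change as from compound 1 to compound 2, not the same: in compound 2 the fluoro sits ortho to a large group, two atoms from the ring nitrogen, whereas in compound 4 it sits next to the ring nitrogen, para to a large group. Only one earlier case exists, so the expectation is loose. The step is expected to be a number 10.8 percentage points lower from compound 3 to compound 4 (beyond the scatter), set beside a number 13.4 percentage points lower from compound 1 to compound 2 (beyond the scatter). This rests on compound 2 with its 86.6%. Compound 4 is expected to give about 75% in this assay, between 60% and 92%.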

Compound 4, a percentage reported as activity, at one concentration (the size of the read-out at that concentration, not a potency): 95.7%
Compound 4: the middle estimate sits 20.7 percentage points below what was measured; measured number outside the range, above it.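

In this assay fluoro in place of hydrogen on an aromatic carbon does not carry over as one fixed step from one core to the other: the same change on two cores in this assay, a number 13.4 percentage points lower (beyond the scatter) from compound 1 to compound 2 and a number 9.9 percentage points higher (within the scatter) from compound 3 to compound 4, 23.3 percentage points apart, beyond the scatter of two such steps. Taken alone, the new result is a number 9.9 percentage points higher from compound 3 to compound 4 (within the scatter) and so shows no firm change on the core of compound 3. The two pairs differ both in core and in where the fluoro sits, in compound 4 next to the ring nitrogen and para to a large group, and two pairs can neither separate these two differences nor say how the change would behave on any further core.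

Left open is how the core of compound 3 responds to a group other than fluoro at this same place, such as chloro or an amine. Also open, on these data alone, is whether the series tolerates a carboxylic acid in place of the methoxy group shared by all four compounds.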